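The compounds below may be only part of what the source reports. "The series", "measured", "known", "first", "only" and "open" are said of these compounds alone.

The two compounds measured so far in an assay on isolated protein (Asteroidea) for inhibition of G2/mitotic-specific cyclin-B (Asterina pectinifera), read by scintillation counting and 33P incorporation, with a stated time of 30 min; on this read-out higher numbers stand for weaker inhibition and lower numbers for stronger inhibition:

Compound 1, `CCC[C@@H](O)Nc1nc(Nc2ccc(-c3ncccn3)cc2)c2ncn(C(C)C)c2n1`: 180 nM
Compound 2, `CCC[C@@H](O)Nc1nc(Nc2ccc(-c3cncnc3)cc2)c2ncn(C(C)C)c2n1`: 40 nM

Within the data shown here, compound 2 holds the lowest of the two numbers in this assay; its nearest neighbour is compound 1, and the only measured step, a 4.5-fold lower number from compound 1 to compound 2 (0.65 log units; beyond the scatter), separates them. That step lies beyond the scatter and concerns the aromatic substituent on the shared core.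

Compound 3, `CC(C)C[C@H](O)Nc1nc(Nc2ccc(-c3cncnc3)cc2)c2ncn(C(C)C)c2n1`, is not yet measured. It differs from compound 2 at a different place: 1-hydroxy-3-methylbutyl in place of 1-hydroxybutyl on a nitrogen on an aromatic ring. Among the measured compounds shown here, no measured step touches this part of the molecule, so the step from compound 1 to compound 2 gives no guidance on the direction or size of the change here. The aromatic substituent that distinguished compound 2 from compound 1 is kept in compound 3, which is the main ground for expecting compound 3 to sit near compound 2.

With nothing to indicate a shift, the step of no change at the digits printed from compound 2 to compound 3 (within the scatter) is expected to stay within the scatter. Compound 3 is therefore estimated at 40 nM in this assay, with a range from 15 nM to 110 nM.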

Compound 3, half-maximal inhibitory concentration: 270 nM
Compound 3: middle estimate off by 6.8-fold (0.83 log units), on the low side; the measured number lies above the stated range.
By their numbers in this assay, from the lowest: compound 2; then compounds 1 and 3 (each within the scatter of the next).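

In this assay, the chain on the nitrogen turns out to matter, a point the earlier pair could not show: with pyrimidin-5-yl held constant, the change gives a 6.8-fold higher number from compound 2 to compound 3 (0.83 log units; beyond the scatter) and so moves the read-out towards weaker inhibition. The entering 1-hydroxy-3-methylbutyl has 6 heavy atoms against 5 in the leaving 1-hydroxybutyl, with the same counts of hydrogen-bond donors and acceptors and no net charge on either, but the defined stereocentre is written with the opposite sense in the two structures, so the step cannot be assigned to the branched chain alone. Nothing available gives a reason for the shift.

The compounds shown leave open whether 1-hydroxybutyl and 1-hydroxy-3-methylbutyl would read differently with the stereocentre written the other way, and how a longer unbranched chain such as 1-hydroxypentyl would read on the same nitrogen. They also leave open whether an amine in place of the hydroxyl would be tolerated, and whether the chain change would give a similar step with pyrimidin-2-yl on the shared core.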